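Swapping the dichlorophenyl for a methoxyphenyl on the chalcone-like carbonyl

The compounds below may be only part of what the source reports. "The series", "measured", "known", "first", "only" and "open" are said of these compounds alone.

Compound 2 `COc1cc(-c2cc(/C=C/C(=O)c3ccc(Cl)c(Cl)c3)[nH]n2)cc(OC)c1OC` gives 10100 nM in a functional assay on 786-0 cells (Homo sapiens) for inhibition, read by sulforhodamine B assay, with a stated time of 48 h (on this read-out higher numbers stand for weaker inhibition of growth and lower numbers for stronger inhibition of growth), the highest of the two numbers measured; the nearest is compound 1 `COc1cc(-c2cc(/C=C/C(=O)c3ccc(N)cc3)[nH]n2)cc(OC)c1OC`, which gives 2040 nM. Compound 3 `COc1ccc(C(=O)/C=C/c2cc(-c3cc(OC)c(OC)c(OC)c3)n[nH]2)cc1` differs from compound 2 by 4-methoxyphenyl in place of 3,4-dichlorophenyl on a carbonyl carbon. Going by the values given here, the only measured step that bears on this site is a 5.0-fold higher number from compound 1 to compound 2 (0.69 log units; beyond the scatter), where the 3,4-dichlorophenyl arrived. Removing it again is therefore expected to move the number back down, though with a single step as guide the size is uncertain: the step from compound 2 to compound 3 is estimated at a 2.9-fold lower number from compound 2 to compound 3 (0.46 log units; beyond the scatter). Compound 3 is expected to reach 3500 nM, within 1500 nM to 9000 nM.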

Compound 3, concentration for 50% growth inhibition: 1950 nM
Compound 3: middle estimate off by 1.8-fold (0.25 log units), on the high side; low and high end bracket the measured number.
By their numbers in this assay, from the lowest: compounds 3 and 1 (each within the scatter of the next); then compound 2.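

Replacing 3,4-dichlorophenyl with 4-methoxyphenyl on the carbonyl carbon gives a 5.2-fold lower number from compound 2 to compound 3 (0.71 log units; beyond the scatter), so compound 2 now stands apart from two other compounds rather than one. Methoxy in place of amino on an aromatic carbon gives a 1.0-fold lower number from compound 1 to compound 3 (0.02 log units; within the scatter), so this assay does not separate these two groups. Nothing measured here explains these numbers. On these data alone, it remains open whether a single chlorine on the phenyl ring would give a number closer to compound 2 or to compound 3. A carboxylic acid at that place on the ring is also untested among the compounds shown here.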